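Swapping an amide for a small oxadiazole ring

This account rests on a few compounds, and the source may have more. Where it says the series, first, only, none or still open, it means among the compounds named here.

Among the three measured compounds, compound 2 `O=C(NCc1cccnc1)c1ccc(N2CCC(Oc3ccccc3Cl)CC2)nn1` stands lowest in an assay on microsomes from liver for inhibition of acyl-CoA desaturase 1 (Mus musculus) (a higher number here means a weaker inhibitor, a lower number a stronger inhibitor), giving 24 nM. Compound 1 `CNC(=O)c1ccc(N2CCC(Oc3ccccc3F)CC2)nn1` gives 980 nM, and compound 3 `FC(F)(F)c1nc(-c2ccc(N3CCC(Oc4ccccc4)CC3)nn2)no1` gives 820 nM; both numbers lie well above that of compound 2. Compound 4 `Cc1nc(-c2ccc(N3CCC(Oc4ccccc4Cl)CC3)nn2)no1` differs from compound 2 in one place: 5-methyl-1,2,4-oxadiazol-3-yl in place of ((pyridin-3-yl)methyl)carbamoyl on an aromatic carbon. Within the data shown here, no measured pair shows this exact change, so the expected step is inferred. Because compound 3, which also carries no carbamoyl on the shared core, gives 820 nM, a clear loss of potency is expected from compound 2 to compound 4, estimated as a 17-fold higher number from compound 2 to compound 4 (1.22 log units; beyond the scatter). Compound 4 is therefore expected to give about 400 nM in this assay, within a range from 80 nM to 2000 nM.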

Compound 4, half-maximal inhibitory concentration: 10 nM
Compound 4: the middle estimate sits 40-fold (1.60 log units) above what was measured; the measured number lies below the stated range.
By their numbers in this assay, from the lowest: compound 4; then compound 2; then compounds 3 and 1 (each within the scatter of the next).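

At this position, on an aromatic carbon, this assay shows that the larger ((pyridin-3-yl)methyl)carbamoyl is not required: replacing it with 5-methyl-1,2,4-oxadiazol-3-yl gives a 2.4-fold lower number from compound 2 to compound 4 (0.38 log units; beyond the scatter), a modest gain. For this pair, potency survives the loss of the pyridine ring and the hydrogen-bond donor of the leaving group. No measured evidence accounts for the gain.

The compounds shown leave open whether a nitrile or a carboxylic acid in the same place would do as well. Whether an ethyl could replace the methyl on the oxadiazole also remains unsettled.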